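The source may hold more compounds than are shown below. What is called first, only, known or untested is meant among the compounds shown, and "the series" means these compounds.

Compound 1 `C/C=C1/[C@H](O[C@@H]2O[C@H](COC(C)=O)[C@@H](OC(C)=O)[C@H](OC(C)=O)[C@H]2OC(C)=O)OC=C(C(=O)OC)[C@H]1CC(=O)OCCC` is a peracetylated glycoside bearing a propyl ester on its side chain. In a functional assay on SK-BR-3 cells (Homo sapiens) for antiproliferative activity, read by MTT assay, with a stated time of 72 h (a lower number here means a stronger inhibitor, a higher number a weaker inhibitor), compound 1 gives 6600 nM, the lowest of the two numbers measured here. Compound 2 `C/C=C1/[C@H](O[C@@H]2O[C@H](CO)[C@@H](O)[C@H](O)[C@H]2O)OC=C(C(=O)OC)[C@H]1CC(=O)OCCc1ccc(O)c(O)c1` carries a free sugar and a 3,4-dihydroxyphenyl group, and in this assay compound 2 gives 160000 nM. Compound 3 `C/C=C1/[C@H](O[C@@H]2O[C@H](CO)[C@@H](O)[C@H](O)[C@H]2O)OC=C(C(=O)OC)[C@H]1CC(=O)OCCc1ccc(F)cc1` gives > 20000 nM in this assay, which is a limit of the assay rather than a number. The step that the limit leaves unreadable from compound 2 to compound 3 therefore cannot be read, because the limit of > 20000 nM in this assay, at which 1 of the 3 values shown sits, hides its size. Compound 4 `C/C=C1/[C@H](O[C@@H]2O[C@H](COC(C)=O)[C@@H](OC(C)=O)[C@H](OC(C)=O)[C@H]2OC(C)=O)OC=C(C(=O)OC)[C@H]1CC(=O)OCC` differs from compound 1 only by hydrogen in place of methyl on a saturated chain carbon, two bonds along the chain from an oxygen next to a carbonyl group. Within the data shown here, no measured step bears on this small trimming, so no change beyond the scatter is expected, and the step of a 1.1-fold higher number from compound 1 to compound 4 (0.03 log units; within the scatter) is estimated to be slight. Compound 4 is expected to give 7000 nM, within 2500 nM to 19000 nM.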

Compound 4, half-maximal inhibitory concentration: > 15000 nM
Compound 4 was reported as a limit; the forecaster's own chance of this, stated with the estimate: 10%; middle value at least 2.1-fold (0.33 log units) from the limit.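

In this assay, trimming propyl to ethyl on the peracetylated glycoside gives an at least 2.2-fold higher number from compound 1 to compound 4 (0.35 log units; beyond the scatter), the only step shown at this position, on a saturated chain carbon, two bonds along the chain from an oxygen next to a carbonyl group. Losing this one methyl is thus enough to move the number beyond the scatter. Going by these compounds, the full size of the step stays unknown, since compound 4 stands at a limit: the limit of > 15000 nM in this assay, at which 1 of the 4 values shown sits.

The compounds shown leave open whether a longer chain, such as butyl, would give a lower number than compound 1. They also leave open how an amine at the end of this chain would read.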